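A few compounds are considered here, and "the series" means these few. Any claim that something is new, unique, unknown or untested is made for them only; others in the source may bear on it.

Three hydroxyphenyl-substituted analogues sharing one core were examined in a functional assay on HCT-15 cells (Homo sapiens) for cytotoxicity, read by CCK-8 assay, with a stated time of 4 days; on this read-out lower numbers stand for stronger inhibition and higher numbers for weaker inhibition. Compound 1 `Oc1ccc(-c2cc(-c3ccc(O)cc3)nc(-c3ccc(O)cc3)c2)cc1` gives 5120 nM in this assay. Compound 2 `Oc1ccc(-c2cc(-c3cccc(O)c3)nc(-c3cccc(O)c3)c2)cc1` gives 3810 nM. Compound 3 `Oc1ccc(-c2cc(-c3cccc(O)c3)cc(-c3cccc(O)c3)n2)cc1` gives 3090 nM, the lowest of the three numbers, though its gap to compound 2 and its gap to compound 1 both lie within the scatter of repeated measurements, so the three compounds cannot be ranked against one another on these data.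

Compound 4 `Oc1ccc(-c2cc(-c3ccc(O)cc3)nc(-c3cccc(O)c3)c2)cc1` has not yet been measured in this assay. It is built from the same atoms as compound 3, joined differently: 4-hydroxyphenyl in place of 3-hydroxyphenyl on an aromatic carbon. Going by the values given here, no step between two measured compounds isolates this exact change, so there is no measured precedent to lean on; what the three measured compounds show is that rearranging hydroxyl positions on the three aryl groups moves the number by no more than the scatter. Compound 4 is therefore expected to land close to compound 3, with a step of a 1.2-fold higher number from compound 3 to compound 4 (0.09 log units; within the scatter) that is not expected to exceed the scatter in either direction. The estimate for compound 4 in this assay is 3800 nM, within a range from 1900 nM to 7600 nM.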

Compound 4, half-maximal inhibitory concentration: 3520 nM
The estimate for compound 4 lay 1.1-fold (0.03 log units) above the measured number; low and high end bracket the measured number.
By their numbers in this assay, from the lowest: compounds 3, 4, 2 and 1 (each within the scatter of the next).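

In this assay, going by these compounds alone, the step of a 1.1-fold higher number from compound 3 to compound 4 (0.06 log units; within the scatter) is the first measured one to isolate 4-hydroxyphenyl in place of 3-hydroxyphenyl on the aromatic carbon opposite the ring nitrogen, and it stays within the scatter. The same kind of exchange on an aromatic carbon gives a 1.1-fold lower number from compound 2 to compound 4 (0.03 log units; within the scatter) and, in the reverse sense, a 1.5-fold lower number from compound 1 to compound 4 (0.16 log units; within the scatter) so none of the three single-place exchanges separates one hydroxyl placement from the other. No measured evidence is available to explain why these numbers stay so close.

Going by these compounds, whether a methoxy group, an amine or a carboxylic acid in place of the hydroxyl would shift the number beyond the scatter stays open. Also open, on these data alone, is whether an unsubstituted phenyl group at the same carbon would do so.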